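A few compounds are considered here, and "the series" means these few. Any claim that something is new, unique, unknown or untested is made for them only; others in the source may bear on it.

Measured so far:
compound 1, `CCCCCCCCCCCCCC(=O)Nc1nnc(S[C@@H]2O[C@H](COC(C)=O)[C@H](OC(C)=O)[C@H](OC(C)=O)[C@H]2OC(C)=O)s1`: 61300 nM
compound 2, `CCCCCCCC/C=C\CCCCCCCCCCCC(=O)Nc1nnc(S[C@@H]2O[C@H](COC(C)=O)[C@H](OC(C)=O)[C@H](OC(C)=O)[C@H]2OC(C)=O)s1`: 58500 nM
compound 3, `CCCCCCCCCCCCCC(=O)Nc1nnc(S[C@@H]2O[C@H](CO)[C@H](O)[C@H](O)[C@H]2O)s1`: 31000 nM

All three values come from a functional assay on HeLa cells (Homo sapiens) for cytotoxicity, read by MTT assay, with a stated time of 24 h; on this read-out lower numbers stand for stronger inhibition and higher numbers for weaker inhibition. The change from compound 1 to compound 2 is dec-1-en-1-yl in place of ethyl on a saturated chain carbon, ten or more bonds along the chain from a carbonyl carbon; in this assay it gave a 1.0-fold lower number from compound 1 to compound 2 (0.02 log units; within the scatter), so the longer unsaturated chain left the read-out essentially where it was. Compound 3 carries the same acyl chain as compound 1 on a different core; the difference between the two cores is not broken down here. In this assay compound 3 gives 31000 nM, and both compound 2 and compound 1 sit within the scatter of that value, so no ordering among the three is claimed.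

Compound 4, `CCCCCCCC/C=C\CCCCCCCCCCCC(=O)Nc1nnc(S[C@@H]2O[C@H](CO)[C@H](O)[C@H](O)[C@H]2O)s1`, is not yet measured. Relative to compound 3 it shows dec-1-en-1-yl in place of ethyl on a saturated chain carbon, ten or more bonds along the chain from a carbonyl carbon: the same change already seen between compound 1 and compound 2, at the same place. The expectation for the step is set by that earlier pair, because on the other core the change gave a 1.0-fold lower number from compound 1 to compound 2 (0.02 log units; within the scatter). On the core of compound 3 the same change is therefore expected to give a 1.0-fold lower number from compound 3 to compound 4 (0.01 log units; within the scatter), a step of about the same small size. Compound 4 is estimated at 30000 nM, expected to fall between 13000 nM and 70000 nM.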

Compound 4, half-maximal inhibitory concentration: 13500 nM
The estimate for compound 4 lay 2.2-fold (0.35 log units) above the measured number; the range from low to high includes it.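

In this assay, dec-1-en-1-yl in place of ethyl on the core of compound 3 gave a 2.3-fold lower number from compound 3 to compound 4 (0.36 log units; beyond the scatter). Set beside the same change on the core of compound 1, this step is not distinguishable from the earlier one: the same change on two cores in this assay, a 1.0-fold lower number (0.02 log units; within the scatter) from compound 1 to compound 2 and a 2.3-fold lower number (0.36 log units; beyond the scatter) from compound 3 to compound 4, 2.2-fold (0.34 log units) apart, within the scatter of two such steps The two pairs are therefore compatible with the change carrying over between these cores, but a single pair on each core does not establish that it carries over equally, or that the core of compound 3 responds more strongly.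

The change brings added chain length and a double bond together, and the compounds shown do not separate the two contributions. Also open, from the compounds shown here alone, is how a longer saturated chain, an amine or a carboxylic acid in place of ethyl at the same place would read in this assay, and whether the comparison would hold on any further core.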